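The source may hold more compounds than are shown below. What is called first, only, known or untested is meant among the compounds shown, and "the series" means these compounds.

Measured so far in a functional assay on DU-145 cells (Homo sapiens) for inhibition, read by WST assay, with a stated time of 3 days; a lower number here means a stronger inhibitor, a higher number a weaker inhibitor:
compound 1 `CC(C)n1ccnc1/C=C/C(=O)/C=C/c1coc2ccccc2c1=O` – 3300 nM
compound 2 `CCCC(C)n1ccnc1/C=C/C(=O)/C=C/c1coc2ccccc2c1=O` – 1400 nM

Among the compounds with values here, compound 2 holds the lower of these two numbers, at 1400 nM, and compound 1 is its only measured neighbour. The next compound to be tested is compound 3 `CCC(CC)n1ccnc1/C=C/C(=O)/C=C/c1coc2ccccc2c1=O`, which has the same atoms as compound 2, joined differently: pentan-3-yl in place of 1-methylbutyl on an aromatic nitrogen. In words, pentan-3-yl stands in place of 1-methylbutyl on an aromatic nitrogen, while the rest of the molecule is unchanged.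

Within the data shown here, only one measured step bears on this change. It is a 2.4-fold lower number from compound 1 to compound 2 (0.37 log units; beyond the scatter), a modest step just beyond the scatter, which came with ethyl in place of hydrogen on a saturated chain carbon. That step added carbon, whereas the new change adds none and only rearranges the same chain atoms. Among the measured compounds shown here, since the one chain change on record, for compound 2, was only a 2.4-fold lower number from compound 1 to compound 2 (0.37 log units; beyond the scatter), a smaller move is expected here in this assay, with nothing beyond the scatter and no firm direction.

The expected step is a 1.1-fold higher number from compound 2 to compound 3 (0.03 log units; within the scatter). For compound 3 the estimated value is 1500 nM, with an expected range from 700 nM to 3200 nM.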

Compound 3, half-maximal inhibitory concentration: 5200 nM
The estimate for compound 3 lay 3.5-fold (0.54 log units) below the measured number; measured number outside the range, above it.
By their numbers in this assay, from the lowest: compound 2; then compounds 1 and 3 (each within the scatter of the next).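

In this assay this position on an aromatic nitrogen responds to how the chain carbons are joined and not only to how many there are: moving from 1-methylbutyl to pentan-3-yl, with the same atoms, gives a 3.7-fold higher number from compound 2 to compound 3 (0.57 log units; beyond the scatter) and takes back the gain seen earlier. Pentan-3-yl in place of isopropyl gives a 1.6-fold higher number from compound 1 to compound 3 (0.20 log units; within the scatter) and so no readable change, whereas 1-methylbutyl in place of isopropyl gave a 2.4-fold lower number from compound 1 to compound 2 (0.37 log units; beyond the scatter), which means that compound 3 goes against any reading of that earlier step as a gain from added carbon alone. No measurement at hand accounts for the difference between these two arrangements of the chain.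

The three compounds shown leave open whether the lower number of compound 2 depends on its branch point or on the length of its longest arm, which an unbranched pentyl chain or a longer 1-methylpentyl chain on the same nitrogen would test. They also leave open how a closed cyclopentyl ring, or a chain ending in a hydroxyl group or an amine, would behave at this position on the shared core.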